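Aryl ether in place of cycloalkyl ether: expected cytotoxicity

The source may report more compounds than this note shows. Statements on the series, on what has been measured and on what is new or still open speak of the compounds shown alone.

Going by the values given here, compound 1 `Cc1cn(C2CCN(Cc3cccc(OC4CCCC4)c3)CC2)c(=O)[nH]c1=O` is the only member of this set with a number in an ADME assay on MRC5 cells (Homo sapiens) for cytotoxicity, read by fluorescence and resazurin assay, with a stated time of 3 days; on this read-out lower numbers stand for stronger inhibition and higher numbers for weaker inhibition; in this assay compound 1 gives 30300 nM. Compound 2 `Cc1cn(C2CCN(Cc3cccc(Oc4ccc(O)cc4)n3)CC2)c(=O)[nH]c1=O` was also examined, but in this assay compound 2 gives "not determined" (no result reported) and so adds no number. Compound 3 `Cc1cn(C2CCN(Cc3cccc(Oc4ccccn4)c3)CC2)c(=O)[nH]c1=O` differs from compound 1 by pyridin-2-yl in place of cyclopentyl on an oxygen on an aromatic ring on the same core. Among the compounds with values here, no step between measured compounds is available, so the expectation rests on this one change alone: the step is expected to be small, a 1.3-fold higher number from compound 1 to compound 3 (0.12 log units; within the scatter), within or barely beyond the scatter, leaning toward weaker inhibition. In this assay compound 3 is expected to give 40000 nM with a range from 15000 nM to 100000 nM.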

Compound 3, half-maximal inhibitory concentration: > 64000 nM
Compound 3 was reported as a limit; the forecaster's own chance of this, stated with the estimate: 30%; at least 1.6-fold (0.20 log units) between middle value and limit.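

Going by these compounds alone, on an oxygen on an aromatic ring, pyridin-2-yl in place of cyclopentyl gives the first measured change at this position, and it goes toward weaker inhibition in this assay: an at least 2.1-fold higher number from compound 1 to compound 3 (0.32 log units; beyond the scatter). The value of compound 3, > 64000 nM, is a limit and not a number. The size of the step is therefore bounded on one side only: the limit of > 64000 nM in this assay, at which 1 of the 3 values shown sits.

The compounds shown leave open how far the true value of compound 3 lies past that limit. They also leave open whether a pyridin-3-yl or a plain phenyl on the same oxygen would behave like pyridin-2-yl.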